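From Chloro to Nitro: Does Red-Cell Damage Change?

The source may report more compounds than this note shows. Statements on the series, on what has been measured and on what is new or still open speak of the compounds shown alone.

Compound 1 `CC(=NNC(=S)Nc1ccc(Cl)cc1)c1ccccn1` was tested in an ADME assay on cells (Erythrocyte, Homo sapiens), read by hemolysis, with a stated time of 1 h; on this read-out higher numbers stand for weaker inhibition and lower numbers for stronger inhibition. In this assay compound 1 gives > 10000 nM, which is a limit of the assay rather than a measured number. Compound 2 `CC(=NNC(=S)Nc1cccc([N+](=O)[O-])c1)c1ccccn1` likewise gives > 10000 nM, again only a limit. Compound 1 therefore sits at the limit of > 10000 nM in this assay, at which 2 of the 2 values shown sit. Compound 3 `CC(=NNC(=S)Nc1ccc([N+](=O)[O-])cc1)c1ccccn1` differs from compound 1 by nitro in place of chloro on an aromatic carbon. For the measured compounds named here, no measured pair shows the effect of this swap, so no step beyond the usual scatter is expected in this assay, in either direction. Compound 3 is expected to give 20000 nM, within a range from 10000 nM to 100000 nM. The expected change is a step that the limit leaves unreadable from compound 1 to compound 3.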

Compound 3, half-maximal inhibitory concentration: > 10000 nM
Compound 3: no number, only a limit (the forecaster's own chance of this, stated with the estimate: 85%); the middle value lies beyond the limit too.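

In this assay, no step can be read between compound 1 and compound 3, as each gives only a limit: the limit of > 10000 nM in this assay, at which 3 of the 3 values shown sit. The compounds shown leave open whether nitro in place of chloro changes red-cell damage at all.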